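From 4-chlorophenyl to 4-methoxyphenyl: a step among limits

The source may report more compounds than this note shows. Statements on the series, on what has been measured and on what is new or still open speak of the compounds shown alone.

Compounds measured in a functional assay on MCF7 cells (Homo sapiens) for cytotoxicity, read by MTT assay (on this read-out higher numbers stand for weaker inhibition and lower numbers for stronger inhibition), each value a limit and not a number:

Compound 1 `COc1cc2ncnc(Nc3cc(O)[nH]n3)c2cc1OC`: < 100000 nM
Compound 2 `COc1cc2ncnc(Nc3cc(-c4ccccc4)[nH]n3)c2cc1OC`: < 100000 nM
Compound 3 `COc1cc2ncnc(Nc3cc(-c4ccc(Cl)cc4)[nH]n3)c2cc1OC`: < 100000 nM

In this assay, compound 3 stands only at a limit, < 100000 nM. The two other compounds are no different, and the whole record comes down to the limit of < 100000 nM in this assay, at which 3 of the 3 values shown sit.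

Compound 4 `COc1ccc(-c2cc(Nc3ncnc4cc(OC)c(OC)cc34)n[nH]2)cc1` changes one group of compound 3: methoxy in place of chloro on an aromatic carbon, para to a large group (methoxy in place of chloro on an aromatic carbon).

The measured change closest to this one, chloro in place of hydrogen on an aromatic carbon, is a step that the two limits leave unreadable from compound 2 to compound 3. The two changes that replace hydroxy are a step that the two limits leave unreadable from compound 1 to compound 2 and a step that the two limits leave unreadable from compound 1 to compound 3. None of the three has a size that can be carried over to the new change, and none shows a direction. The expected change is therefore a step that the limit leaves unreadable from compound 3 to compound 4, and this expectation carries no firm direction. The likeliest outcome in this assay is another limit rather than a number. For compound 4 the estimated value is 50000 nM, with an expected range from 10000 nM to 100000 nM.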

Compound 4, half-maximal inhibitory concentration: < 100000 nM
Compound 4 gave a limit, no number; the forecaster's own chance of this, stated with the estimate: 70%; the middle value lies beyond the limit too.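

Compound 4, like compounds 1, 2 and 3, gives only a limit in this assay and no number, so none of its steps to those three compounds can be read: the limit of < 100000 nM in this assay, at which 4 of the 4 values shown sit.

In this assay the compounds shown leave open how strong each one actually is, and whether hydroxy, phenyl, 4-chlorophenyl and 4-methoxyphenyl differ at all.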